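Stilbene-cinnamamide series: trifluoromethyl to cyano swap

The source may report more compounds than this note shows. Statements on the series, on what has been measured and on what is new or still open speak of the compounds shown alone.

Measured compounds:
Compound 1 `COc1cc(/C=C/c2ccc(NC(=O)/C=C/c3cc(OC)c(O)c(OC)c3)cc2)cc(OC)c1` — 3080 nM
Compound 2 `COc1cc(/C=C/c2ccc(NC(=O)/C=C/c3ccc(C(F)(F)F)cc3)cc2)cc(OC)c1` — 1780 nM

In a functional assay on HT-29 cells (Homo sapiens) for inhibition, read by MTT assay, with a stated time of 48 h (a higher number here means a weaker inhibitor, a lower number a stronger inhibitor), compound 1 gives 3080 nM and compound 2 gives 1780 nM. Compound 2 has the lowest number of the two, but the step of a 1.7-fold lower number from compound 1 to compound 2 (0.24 log units; within the scatter) lies within the scatter, so the two are not distinguished on the numbers available.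

Compound 3 `COc1cc(/C=C/c2ccc(NC(=O)/C=C/c3ccc(C#N)cc3)cc2)cc(OC)c1` has not been measured. Its difference from compound 2 is cyano in place of trifluoromethyl on an aromatic carbon, para to a large group. Among the measured compounds shown here, no measured step alters this position alone; the only step in hand, the exchange of the whole aryl group from compound 1 to compound 2, gave a 1.7-fold lower number from compound 1 to compound 2 (0.24 log units; within the scatter), a change within scatter. A smaller change at the same ring is therefore expected to move this assay little, and no direction beyond the scatter is expected; the expected step is a 1.1-fold higher number from compound 2 to compound 3 (0.03 log units; within the scatter). Compound 3 is estimated at 1900 nM, in the range 700 nM to 5000 nM.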

Compound 3, half-maximal inhibitory concentration: 3320 nM
Estimate against measurement, compound 3: 1.7-fold (0.24 log units) below; measured number inside the range.
By their numbers in this assay, from the lowest: compounds 2, 1 and 3 (each within the scatter of the next).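

In this assay, the exchange of trifluoromethyl for cyano on this aromatic carbon gives a 1.9-fold higher number from compound 2 to compound 3 (0.27 log units; within the scatter) and so does not separate the two groups, although 4 heavy atoms give way to 2 and 1 hydrogen-bond acceptor enters. Exchanging the whole aryl group, with 4-cyanophenyl in place of 4-hydroxy-3,5-dimethoxyphenyl, gives a 1.1-fold higher number from compound 1 to compound 3 (0.03 log units; within the scatter) and likewise does not separate the two, so all three aryl groups in hand now lie within the scatter of one another. No measurement bearing on the cause of these numbers is available.

Going by these compounds, it remains open whether an amine, a carboxylic acid or a longer chain on this aromatic carbon would give a step beyond the scatter in this assay. On these data alone, it also remains open whether any change on the shared core outside this ring would do so.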